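A Methyl on the Ring Amine of Compound 1

The source may report more compounds than this note shows. Statements on the series, on what has been measured and on what is new or still open speak of the compounds shown alone.

Compound 1 `CN1CCN(CCCN(C[C@H]2Cc3ccccc3CN2)[C@H]2CCCc3cccnc32)CC1` is the starting point. Going by the values given here, in an ADME assay for permeability, using PAMPA, with a stated time of 4 h, at pH 7.4 (a lower number here means that the compound crosses the layer more slowly, a higher number that the compound crosses the layer faster), compound 1 gives 360 nm/s, the highest of the three numbers measured so far. Compound 2 `c1ccc2c(c1)CN[C@@H](CN(CC[C@H]1CCCNC1)[C@H]1CCCc3cccnc31)C2` gives 55 nm/s, and compound 3 `CC(C)N1CCN(CCCN(C[C@H]2Cc3ccccc3CN2)[C@H]2CCCc3cccnc32)CC1` gives 344 nm/s. The step of a 6.5-fold lower number from compound 1 to compound 2 (0.82 log units; beyond the scatter) exchanged the group on a saturated chain carbon, whereas a 1.0-fold lower number from compound 1 to compound 3 (0.02 log units; within the scatter) touched only an amine nitrogen in a ring. Compound 4 `CN1CCN(CCCN(C[C@H]2Cc3ccccc3CN2C)[C@H]2CCCc3cccnc32)CC1` differs from compound 1 by methyl in place of hydrogen on an amine nitrogen in a ring. The step from compound 1 to compound 3, also a change on an amine nitrogen in a ring, is the one that bears on this, and it stayed within the scatter. A step within the scatter is therefore expected, a 1.2-fold higher number from compound 1 to compound 4 (0.08 log units; within the scatter). Compound 4 is estimated at 430 nm/s, between 230 nm/s and 800 nm/s.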

Compound 4, apparent permeability: 513 nm/s
Estimate against measurement, compound 4: 1.2-fold (0.08 log units) below, and the stated range covers the measured number.
By their numbers in this assay, from the lowest: compound 2; then compounds 3, 1 and 4 (each within the scatter of the next).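

Going by these compounds alone, until now, the only change on an amine nitrogen in a ring lay elsewhere in the molecule; compound 4 carries its methyl on the nitrogen next to the ring atom that bears a large group. Even at this crowded-looking place, the methyl gives only a 1.4-fold higher number from compound 1 to compound 4 (0.15 log units; within the scatter) in this assay, so this hydrogen can be replaced by methyl with no change beyond the scatter. No measurement here offers an explanation for this result. On these data alone, whether an acetyl or benzyl group on this nitrogen would behave the same remains open.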